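Adding one methyl to compound 2: working notes

A few compounds are considered here, and "the series" means these few. Any claim that something is new, unique, unknown or untested is made for them only; others in the source may bear on it.

Of the compounds shown here, two carry numbers so far in a functional assay on A2780cisR cells (Homo sapiens) for antiproliferative activity, read by MTT assay, with a stated time of 72 h; a lower number here means a stronger inhibitor, a higher number a weaker inhibitor. Compound 1 (`O=C(CCCCCONC(=O)Nc1ccc2ccccc2c1)NO`) gives 1600 nM, and compound 2 (`O=C(CCCCCONC(=O)Nc1cccc2cccnc12)NO`) gives 1000 nM. These two values lie within the usual scatter of each other, so compound 2 stands level with compound 1 on the present numbers.

The next compound is compound 3 (`Cc1ccc2cccc(NC(=O)NOCCCCCC(=O)NO)c2n1`), which keeps the core and the chain of compound 2. The change is methyl in place of hydrogen on an aromatic carbon, next to the ring nitrogen.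

For the measured compounds named here, no two measured compounds differ in one place, so the series offers no direct measure of a methyl step in this assay. The expectation therefore rests on compound 2 at 1000 nM, with no move beyond the scatter expected in either direction. The estimated size is no change at the digits printed from compound 2 to compound 3 (within the scatter), which would leave the series about where it stands. For compound 3 the expected value is 1000 nM, with an estimated range of 400 nM to 2500 nM.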

Compound 3, half-maximal inhibitory concentration: 1300 nM
For compound 3 the middle estimate is 1.3-fold (0.11 log units) below the measured one; low and high end bracket the measured number.
By their numbers in this assay, from the lowest: compounds 2, 3 and 1 (each within the scatter of the next).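

In this assay, for the compounds shown here, methyl in place of hydrogen on an aromatic carbon, next to the ring nitrogen, gives a 1.3-fold higher number from compound 2 to compound 3 (0.11 log units; within the scatter), and this is the first step that differs in one place only. The earlier compounds shown here gave no reading at this position, and this step shows that the single added carbon leaves the number within the scatter, so compound 3 stands level with compound 2 and this position can carry a methyl without a measurable move in this antiproliferative read-out. No measurement on hand bears on why the step is this small.

The compounds shown leave open whether the flat result belongs to methyl alone or holds for other groups at this position, such as an amine, a carboxylic acid, a methoxy group or a longer alkyl chain, any of which could still move the number beyond the scatter. They also leave open whether methyl on the other aromatic carbons of the shared core would behave as it does here, since this single step speaks for one position and one group only.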